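The source may report more compounds than this note shows. Statements on the series, on what has been measured and on what is new or still open speak of the compounds shown alone.

Three compounds with a shared core were tested in a functional assay on A-375 cells (Homo sapiens) for antiproliferative activity, read by MTT assay, with a stated time of 24 h, tested at 0.41 ug/mL; a lower number here means a weaker effect, a higher number a stronger effect of the compound at the concentration tested. Compound 1 `CCc1ccc2nc(C(=O)Nc3c(F)cc(-c4cccc(F)c4)cc3F)c(C)c(O)c2c1` gives 3.56% in this assay. Compound 2 `Cc1c(C(=O)Nc2ccc(-c3ccccc3)cc2)nc2ccccc2c1O` gives 2.65% in this assay. Compound 3 `CCc1ccc2nc(C(=O)Nc3c(F)cc(-c4cccc(F)c4)cc3F)c(C)c(C(=O)O)c2c1` gives 6.13% in this assay. The numbers of compound 1, compound 2 and compound 3 all lie within the usual scatter of one another, so compound 3 does not stand apart from either of the other two. Among the measured compounds shown here, the one single-point step measured so far, a number 2.6 percentage points higher from compound 1 to compound 3 (within the scatter), lies within the scatter as well.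

Compound 4 `Cc1c(C(=O)Nc2c(F)cc(-c3cccc(F)c3)cc2F)nc2ccc(C(F)(F)F)cc2c1C(=O)O` has not yet been measured. It differs from compound 3 in one place: trifluoromethyl in place of ethyl on an aromatic carbon. For the measured compounds named here, no measured step concerns an exchange at that place; the only measured step, a number 2.6 percentage points higher from compound 1 to compound 3 (within the scatter), concerns a different group and stayed within the scatter, and the changes among the measured compounds have moved the read-out little. Compound 4 is therefore expected to show a step of a number 0.1 percentage points lower from compound 3 to compound 4 (within the scatter), nothing beyond the scatter. The estimate for compound 4 in this assay is 6%, expected to fall between -3% and 15%.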

Compound 4, a percentage reported as inhibition, at one concentration (the size of the read-out at that concentration, not a potency): 7.82%
Compound 4: middle estimate off by 1.8 percentage points, on the low side, within the range that was stated.
By their numbers in this assay, from the lowest: compounds 2, 1, 3 and 4 (each within the scatter of the next).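

In this assay, among the compounds shown here, the exchange at this aromatic carbon gives a number 1.7 percentage points higher from compound 3 to compound 4 (within the scatter), the first measured step at this place on the shared core. It shows that trifluoromethyl can stand in place of ethyl here, on a six-membered aromatic ring of carbon only, without moving the read-out beyond the scatter, at least with the carboxy group of compound 3 and compound 4 present. No measurement shown bears on why this exchange has so small an effect.

The compounds shown leave open whether an amine, a methoxy group or a longer chain on this same carbon would move the read-out beyond the scatter. They also leave open whether trifluoromethyl in place of ethyl would give a similar step in the hydroxy series of compound 1.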